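The source may report more compounds than this note shows. Statements on the series, on what has been measured and on what is new or still open speak of the compounds shown alone.

Measured compounds in this assay:
compound 1 `CCCn1ccc2cc(/C(C)=C/C(=O)Nc3ccccc3OCCCC(=O)O)ccc21` — 190 nM
compound 2 `CCCCn1ccc2cc(/C(C)=C/C(=O)Nc3ccccc3OCCCC(=O)O)ccc21` — 43 nM
compound 3 `CCCC(CC)n1ccc2cc(/C(C)=C/C(=O)Nc3ccccc3OCCCC(=O)O)ccc21` — 9.3 nM

In an assay on Prostate gland for inhibition of steroid 5-alpha-reductase (Rattus norvegicus) (on this read-out lower numbers stand for stronger inhibition and higher numbers for weaker inhibition), compound 3 stands lowest of the three numbers: the step of a 4.6-fold lower number from compound 2 to compound 3 (0.66 log units; beyond the scatter) and the step of a 20-fold lower number from compound 1 to compound 3 (1.31 log units; beyond the scatter) both lie beyond the scatter, so compound 3 is the strongest inhibitor of the set. Compound 4 `C/C(=C\C(=O)Nc1ccccc1OCCCC(=O)O)c1ccc2c(ccn2C(C(C)C)C(C)C)c1` differs from compound 3 in one place: 1-isopropyl-2-methylpropyl in place of 1-ethylbutyl on an aromatic nitrogen.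

The measured steps all concern the chain on the aromatic nitrogen. The step of a 4.4-fold lower number from compound 1 to compound 2 (0.65 log units; beyond the scatter) and the step of a 4.6-fold lower number from compound 2 to compound 3 (0.66 log units; beyond the scatter) were each modest, and together they make up the large step of a 20-fold lower number from compound 1 to compound 3 (1.31 log units; beyond the scatter); every addition of carbon to that chain so far has lowered the number. Going by the values given here, the change to compound 4 adds one more heavy atom in the same place but rearranges the chain rather than simply lengthening it, and there is no measured pair that tests such a rearrangement. The expectation is therefore a small further lowering, a 1.6-fold lower number from compound 3 to compound 4 (0.19 log units; within the scatter), which may well fall within the scatter. Compound 4 is estimated at 6 nM, with a range from 2 nM to 20 nM.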

Compound 4, half-maximal inhibitory concentration: 14 nM
For compound 4 the middle estimate is 2.3-fold (0.37 log units) below the measured one, and the stated range covers the measured number.
By their numbers in this assay, from the lowest: compounds 3 and 4 (each within the scatter of the next); then compound 2; then compound 1.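

In this assay the step of a 1.5-fold higher number from compound 3 to compound 4 (0.18 log units; within the scatter) lies within the scatter, so 1-isopropyl-2-methylpropyl and 1-ethylbutyl on the aromatic nitrogen cannot be told apart. Compound 4 therefore goes against the earlier run, in which each addition of carbon to this chain lowered the number. The branched chain still keeps its advantage over the unbranched chains, as shown by a 3.1-fold lower number from compound 2 to compound 4 (0.49 log units; beyond the scatter) and by a 14-fold lower number from compound 1 to compound 4 (1.13 log units; beyond the scatter), both beyond the scatter. Nothing available accounts for the change in this trend.

Still open, from the compounds shown here alone, is how a cyclohexyl ring or a longer branched chain such as 1-propylbutyl on the aromatic nitrogen would compare with 1-ethylbutyl. Also open, going by these compounds, is whether the same ranking of these chains would hold with a tetrazole in place of the carboxylic acid.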